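The compounds below may be only part of what the source reports. "The series", "measured", "known", "first", "only" and "open" are said of these compounds alone.

Measured compounds:
Compound 1, `Cc1ccc(N(C(=O)c2ccccc2C)C(=S)OCCN2C(=O)c3ccccc3C2=O)cc1`: in an ADME assay on MT4 cells (Homo sapiens) for cytotoxicity, read by MTT assay (on this read-out higher numbers stand for lower toxicity in this test and lower numbers for higher toxicity in this test), compound 1 gives > 100000 nM, which is a limit of the assay and not a number.
Compound 2, `O=C1c2ccccc2C(=O)N1CCOC(=S)N(C(=O)c1ccc(Cl)c([N+](=O)[O-])c1)c1ccccc1`: in this assay compound 2 gives 51000 nM.

Going by the values given here, compound 2 holds the only plain number in this set; the other entry is a limit, (the limit of > 100000 nM in this assay, at which 1 of the 2 values shown sits), and no step between measured compounds can be drawn from these two. Compound 2 therefore stands alone as the point of reference for the next compound. Compound 3, `O=C1c2ccccc2C(=O)N1CCOC(=S)N(C(=O)c1ccc(Cl)c([N+](=O)[O-])c1)c1ccc(Cl)cc1`, is not yet measured in this assay. It differs from compound 2 in one place: chloro in place of hydrogen on an aromatic carbon. The change is small in size and leaves the rest of the shared core untouched. Among the compounds with values here, with no measured step of the same kind, the expectation for this assay is a step no larger than the usual scatter, if anything toward a lower number, that is toward higher toxicity in this test. For compound 3 the estimated step from compound 2 is a 1.3-fold lower number from compound 2 to compound 3 (0.11 log units; within the scatter). Compound 3 is expected to give about 40000 nM, between 15000 nM and 120000 nM.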

Compound 3, half-maximal cytotoxic concentration: 48000 nM
Compound 3: middle estimate off by 1.2-fold (0.08 log units), on the low side; low and high end bracket the measured number.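

In this assay, going by these compounds alone, the change from phenyl to 4-chlorophenyl gives the first step, a 1.1-fold lower number from compound 2 to compound 3 (0.03 log units; within the scatter), so chloro in place of hydrogen on this aromatic carbon, para to a large group, leaves the read-out without a shift that can be told from scatter. The earlier compounds shown here offered no step at all, and this position now has one reading: a single chlorine atom can enter here with no visible change in toxicity in this test. Compound 1 carries a limit of the assay and not a number, and it differs from compound 2 in more than one place, so it adds no step to this reading: the limit of > 100000 nM in this assay, at which 1 of the 3 values shown sits.

One chloro group at one position says little about other groups at the same place, such as an amine, a carboxylic acid or a methoxy group, any of which could give a different step. Also open, as far as these compounds go, is whether a longer chain in place of the chloro group, or chloro on another aromatic carbon of the shared core, would stay as close to compound 2 in this assay.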